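A few compounds are considered here, and "the series" means these few. Any claim that something is new, unique, unknown or untested is made for them only; others in the source may bear on it.

In an assay on HEK293 cells for inhibition of nuclear factor NF-kappa-B complex (Homo sapiens), read by a luciferase reporter, with stated times of 1 h and 3 h (on this read-out lower numbers stand for stronger inhibition and higher numbers for weaker inhibition), the three measured compounds give:
compound 1 `CC(C)(C)CNC(=O)C[C@H](NC(=O)CCc1ccccc1)C(=O)N[C@@H](CCc1ccccc1)C(=O)NCc1ccccc1Cl` – 18 nM
compound 2 `CC(C)(C)CNC(=O)C[C@H](NC(=O)C(=O)c1c[nH]c2ccccc12)C(=O)N[C@@H](CCc1ccccc1)C(=O)NCc1ccccc1Cl` – 17 nM
compound 3 `Cc1cc(C(=O)N[C@@H](CC(=O)NCC(C)(C)C)C(=O)N[C@@H](CCc2ccccc2)C(=O)NCc2ccccc2Cl)no1` – 9 nM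

Compound 1 has the highest of the three numbers, yet its steps stay within the scatter: a 1.1-fold lower number from compound 1 to compound 2 (0.02 log units; within the scatter) and a 2.0-fold lower number from compound 1 to compound 3 (0.30 log units; within the scatter). The remaining step, a 1.9-fold lower number from compound 2 to compound 3 (0.28 log units; within the scatter), also lies within the scatter. All three steps alter the group on the carbonyl carbon of the cap. Compound 4 `C[C@H](NC(=O)[C@H](CC(=O)NCC(C)(C)C)NC(=O)CCc1ccccc1)C(=O)NCc1ccccc1Cl` alters a different place: hydrogen in place of benzyl on a saturated chain carbon, two bonds along the chain from an amide-type nitrogen and a carbonyl carbon. For the measured compounds named here, no measured step touches that place, so the measured steps give no direct guide to it, and the question stays open. Compound 4 is expected to give 60 nM, between 12 nM and 300 nM. Compound 4 is thus expected to show a 3.3-fold higher number from compound 1 to compound 4 (0.52 log units; beyond the scatter), leaning toward weaker inhibition but with wide uncertainty.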

Compound 4, half-maximal inhibitory concentration: 10 nM
Estimate against measurement, compound 4: 6.0-fold (0.78 log units) above; the whole stated range lies above it.
By their numbers in this assay, from the lowest: compounds 3, 4, 2 and 1 (each within the scatter of the next).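

Hydrogen in place of benzyl on this saturated chain carbon gives a 1.8-fold lower number from compound 1 to compound 4 (0.26 log units; within the scatter) in this assay. For the compounds shown here, this is the first view of the position, and it shows that the phenethyl of compound 1 can be cut back to the methyl of compound 4, losing its aromatic ring, with a step that stays within the scatter. Nothing available explains this result.

The compounds shown leave open how an amine or a carboxylic acid at this carbon would read. Also open, going by these compounds, is whether the same cut holds alongside the 5-methyl-1,2-oxazol-3-yl group of compound 3.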